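Triazole side-chain swap on the dibenzyloxy furanone core

The compounds below may be only part of what the source reports. "The series", "measured", "known", "first", "only" and "open" are said of these compounds alone.

Compound 2 `O=C1O[C@H]([C@@H](O)Cn2cc(-c3ccc(Br)cc3)nn2)C(OCc2ccccc2)=C1OCc1ccccc1` gives the lowest of the two numbers in a functional assay on HepG2 cells (Homo sapiens) for antiproliferative activity, read by MTT assay, with a stated time of 72 h; on this read-out higher numbers stand for weaker inhibition and lower numbers for stronger inhibition: compound 2 gives 5070 nM. Compound 3 `O=C1O[C@H]([C@@H](O)Cn2cc(-c3cc(C(F)(F)F)cc(C(F)(F)F)c3)nn2)C(OCc2ccccc2)=C1OCc1ccccc1` gives 33800 nM in this assay, a number beyond the scatter above that of compound 2. Compound 1 `O=C1O/C(=C\Cn2cc(-c3ccc(Br)cc3)nn2)C(OCc2ccccc2)=C1OCc1ccccc1`, the unsaturated congener, reaches only a limit of this assay, > 100000 nM, a boundary rather than a number (the limit of > 100000 nM in this assay, at which 1 of the 3 values shown sits). Compound 4 `O=C1O[C@H]([C@@H](O)Cn2cc(CNS(=O)(=O)c3ccc(F)cc3)nn2)C(OCc2ccccc2)=C1OCc1ccccc1` is not yet measured in this assay. It differs from compound 2 by (((4-fluorophenyl)sulfonyl)amino)methyl in place of 4-bromophenyl on an aromatic carbon. Within the data shown here, no step of this kind is measured, so the direction is open; a moderate weakening beyond the scatter is expected, since the one change at this position, compound 3, also weakened. The expected step is a 2.4-fold higher number from compound 2 to compound 4 (0.37 log units; beyond the scatter). Compound 4 is expected at 12000 nM, within 3000 nM to 50000 nM.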

Compound 4, half-maximal inhibitory concentration: 18300 nM
For compound 4 the middle estimate is 1.5-fold (0.18 log units) below the measured one, within the range that was stated.
By their numbers in this assay, from the lowest: compound 2; then compounds 4 and 3 (each within the scatter of the next). At a limit, above all of these: compound 1.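

In this assay, setting (((4-fluorophenyl)sulfonyl)amino)methyl in place of 4-bromophenyl on this aromatic carbon gives a 3.6-fold higher number from compound 2 to compound 4 (0.56 log units; beyond the scatter) as a modest weakening. Compound 4 still gives a number rather than a limit, and it lies within the scatter of compound 3, so two unlike replacements of 4-bromophenyl cannot be told apart here. No measurement shown accounts for this step.

From the compounds shown here alone, whether an amine or a carboxylic acid at this carbon would match compound 2 stays open. So does the effect of a longer chain before the 4-fluorophenyl ring.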